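Shared core ethers: cyclobutyl placed directly on the oxygen

The source may report more compounds than this note shows. Statements on the series, on what has been measured and on what is new or still open speak of the compounds shown alone.

Three measured ethers share one core. In an assay on cells with melanin-concentrating hormone receptor 1 (Homo sapiens) as the target, read by radioligand binding (on this read-out lower numbers stand for stronger inhibition and higher numbers for weaker inhibition), compound 1 `CC(C)(C)CCOc1cccc2ccc(N)nc12` gives 201 nM. Compound 2 `CC1CC1COc1cccc2ccc(N)nc12` gives 1640 nM in this assay, and compound 3 `Nc1ccc2cccc(OCC3CCC3)c2n1` gives 432 nM. Compound 3 thus stands second of the three numbers: there is a 2.1-fold higher number from compound 1 to compound 3 (0.33 log units; beyond the scatter) and a 3.8-fold lower number from compound 2 to compound 3 (0.58 log units; beyond the scatter).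

Compound 4 `Nc1ccc2cccc(OC3CCC3)c2n1` is not yet measured. It differs from compound 3 by cyclobutyl in place of cyclobutylmethyl on an oxygen on an aromatic ring. All three measured steps keep the saturated chain carbon bound to the oxygen and vary only the group on it: an 8.2-fold higher number from compound 1 to compound 2 (0.91 log units; beyond the scatter), a 2.1-fold higher number from compound 1 to compound 3 (0.33 log units; beyond the scatter), a 3.8-fold lower number from compound 2 to compound 3 (0.58 log units; beyond the scatter). For the measured compounds named here, none of them removes that carbon, so the step to compound 4 has no direct precedent here. The measured steps are all modest, and the smallest group, in compound 2, goes with the highest number, 1640 nM, so a modest rise in the number is expected for compound 4 rather than a gain, a 1.9-fold higher number from compound 3 to compound 4 (0.27 log units; within the scatter). In this assay compound 4 is estimated at 800 nM, within 300 nM to 2500 nM.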

Compound 4, half-maximal inhibitory concentration: > 2000 nM
Compound 4 gave a limit, no number; the forecaster's own chance of this, stated with the estimate: 5%; middle value at least 2.5-fold (0.39 log units) from the limit.
By their numbers in this assay, from the lowest: compound 1; then compound 3; then compound 2. At a limit, above all of these: compound 4.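

In this assay compound 4 gives only a limit, > 2000 nM, not a number. For the compounds shown here, this is the first change to remove the saturated chain carbon on the oxygen while keeping the four-membered ring, and the cost is clear: an at least 4.6-fold higher number from compound 3 to compound 4 (0.66 log units; beyond the scatter), and an at least 9.9-fold higher number from compound 1 to compound 4 (0.99 log units; beyond the scatter). Against the weakest measured ether the picture is less sharp, with an at least 1.2-fold higher number from compound 2 to compound 4 (0.08 log units; that floor lies within the scatter), so the data do not separate compound 4 from compound 2.

From the compounds shown here alone, how far the true value of compound 4 lies past its limit remains open, and with it the full size of all three steps. Also open, going by these compounds, is whether a longer chain carrying the cyclobutyl group, or an amine or a carboxylic acid at its end, would lower the number.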